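The source may report more compounds than this note shows. Statements on the series, on what has been measured and on what is new or still open speak of the compounds shown alone.

Compound 1 `O=C(O)c1cc(=O)c2cc(OCCCN3CCC(=C(c4ccccc4)c4ccccc4)CC3)ccc2o1` gives 650 nM in a functional assay (ileum) for inhibition, with Cavia porcellus as the target; a higher number here means a weaker inhibitor, a lower number a stronger inhibitor.
Compound 2 `O=C(O)c1cc(=O)c2ccc(OCCCN3CCC(C(O)(c4ccccc4)c4ccccc4)CC3)cc2o1` gives 22800 nM in this assay.
Compound 3 `O=C(O)c1cc(=O)c2ccc(OCCCN3CCC(OC(c4ccccc4)c4ccccc4)CC3)cc2o1` gives 1450 nM in this assay.

Of the three measured compounds, compound 2 has the highest number and is therefore the weakest inhibitor of the set. Its nearest neighbour in this assay is compound 3, whose number is lower by a margin beyond the scatter, and the gap to compound 1 is wider still. For the measured compounds named here, the three compounds differ from one another in more than one place, so no single step between them is isolated here.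

Compound 4 `O=c1cc(C2N=NN=N2)oc2cc(OCCCN3CCC(C(O)(c4ccccc4)c4ccccc4)CC3)ccc12` keeps everything of compound 2 except one group: a group of 5 heavy atoms (1 carbon, 4 nitrogen; one five-membered non-aromatic ring with 4 hetero atoms) in place of a group of 3 heavy atoms (1 carbon, 2 oxygen; no ring), on an aromatic carbon. Going by the values given here, no measured pair in this set shows this exchange, so the size of its effect is not known from the data. The estimate is that the step from compound 2 to compound 4 will be small, in the direction of a lower number, and not clearly beyond the scatter, giving a 1.9-fold lower number from compound 2 to compound 4 (0.28 log units; within the scatter). Compound 4 is thus expected to give about 12000 nM in this assay, with a range from 3000 nM to 45000 nM, leaving it close to where compound 2 stands.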

Compound 4, half-maximal inhibitory concentration: 56700 nM
Beside the measured number, compound 4's estimate is 4.7-fold (0.67 log units) below it; the whole stated range lies below it.
By their numbers in this assay, from the lowest: compound 1; then compound 3; then compound 2; then compound 4.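

In this assay, putting the five-membered non-aromatic ring with 4 hetero atoms in place of the carboxy group, on the aromatic carbon next to the ring oxygen, leads to a 2.5-fold higher number from compound 2 to compound 4 (0.40 log units; beyond the scatter). For the compounds shown here, this is the only step in the set that changes a single place, and it is the first direct reading of this position: the step is modest but beyond the scatter, so on this compound the carboxy group gives the lower number, while the exchange does not move the number far. Nothing at hand accounts for the direction or size of this step.

As far as these compounds go, the exchange is read on one background only, so whether it would shift the number in the same direction and by a similar amount on compound 1 or compound 3 remains open. Also open, from the compounds shown here alone, is how a methyl ester, a primary amide, a nitrile or an aromatic tetrazole would compare with the carboxy group at this same aromatic carbon.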